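Hexyl to 4,4,4-trifluorobutyl on the shared core

A few compounds are considered here, and "the series" means these few. Any claim that something is new, unique, unknown or untested is made for them only; others in the source may bear on it.

Measured so far in an ADME assay on microsomes from liver (Mus musculus) for metabolic stability, tested at 5 uM; on this read-out lower numbers stand for a shorter-lived compound and higher numbers for a longer-lived compound
- compound 1 `CCCCCCNc1ccc(C(=O)O)cc1S(=O)(=O)NC` gives 0.483 h
- compound 2 `CCCCCCNc1ccc(C(=O)O)cc1S(=O)(=O)N(C)C` gives 0.283 h

In this assay, within the data shown here, compound 2 stands within the scatter of compound 1, the only other measured compound. Among the measured compounds shown here, the one measured step, a 1.7-fold lower number from compound 1 to compound 2 (0.23 log units; within the scatter), is methyl in place of hydrogen on a sulfonamide nitrogen. Compound 3 `CN(C)S(=O)(=O)c1cc(C(=O)O)ccc1NCCCC(F)(F)F` changes a different place, and its hexyl becomes 4,4,4-trifluorobutyl: trifluoromethyl in place of propyl on a saturated chain carbon, three bonds along the chain from a nitrogen on an aromatic ring. For the measured compounds named here, no measured step bears on this chain, so size and direction remain open, with only a modest rise expected. The expected step is a 1.8-fold higher number from compound 2 to compound 3 (0.25 log units; within the scatter). Compound 3 is estimated at 0.5 h, with an expected range of 0.2 h to 1.3 h.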

Compound 3, half-life: > 1 h
Compound 3 ended at the assay's limit (the forecaster's own chance of this, stated with the estimate: 5%); middle value at least 2.0-fold (0.30 log units) away from the limit.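

Exchanging hexyl for 4,4,4-trifluorobutyl on the shared core gives an at least 3.5-fold higher number from compound 2 to compound 3 (0.54 log units; beyond the scatter) in this assay. The chain is thus a place where a single change moves this read-out beyond the scatter, which the step on the sulfonamide nitrogen did not show. Compound 3 gives > 1 h, a limit of the assay and not a number: the limit of > 1 h in this assay, at which 1 of the 3 values shown sits.

From the compounds shown here alone, how far compound 3 lies past that limit stays open. Among these compounds, the one step also changes both the chain length and its end, so a plain butyl chain or a longer chain ending in trifluoromethyl would be needed to separate the two.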